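The compounds below may be only part of what the source reports. "The series", "measured", "known", "first", "only" and "open" are said of these compounds alone.

In a functional assay on MCF7 cells (Homo sapiens) for antiproliferative activity, read by MTT assay, with a stated time of 48 h (a higher number here means a weaker inhibitor, a lower number a stronger inhibitor), compound 1 `CNCC(=O)Nc1cc(OC)ccc1C(=O)c1ccc2c(c1)C=CC(C)(C)O2` gives 1210 nM. Compound 2 `CCNCC(=O)Nc1cc(OC)ccc1C(=O)c1ccc2c(c1)C=CC(C)(C)O2` carries methyl in place of hydrogen on a saturated chain carbon bound to an amine nitrogen and in this assay gives 6310 nM, so that a 5.2-fold higher number from compound 1 to compound 2 (0.72 log units; beyond the scatter). Compound 3 `CNCC(=O)Nc1cc(OC)ccc1C(=O)c1cc(OC)c(OC)c(OC)c1` rests on a different core; the difference between the two cores is not broken down here. In this assay compound 3 gives 550 nM, the lowest number of the three measured. Compound 4 `CCNCC(=O)Nc1cc(OC)ccc1C(=O)c1cc(OC)c(OC)c(OC)c1` is derived from compound 3 by methyl in place of hydrogen on a saturated chain carbon bound to an amine nitrogen, the same change as that made from compound 1 to compound 2. Because a 5.2-fold higher number from compound 1 to compound 2 (0.72 log units; beyond the scatter) gave a modest loss, a step of similar size is expected for compound 4 in this assay, namely a 5.1-fold higher number from compound 3 to compound 4 (0.71 log units; beyond the scatter). Compound 4 is therefore estimated at 2800 nM, most likely falling between 1200 nM and 7000 nM.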

Compound 4, half-maximal inhibitory concentration: 1050 nM
For compound 4 the middle estimate is 2.7-fold (0.43 log units) above the measured one; the whole stated range lies above it.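

In this assay the change from methylamino to ethylamino gives a 1.9-fold higher number from compound 3 to compound 4 (0.28 log units; within the scatter), so the size of the earlier step did not carry over from one core to the other: the same change on two cores in this assay, a 5.2-fold higher number (0.72 log units; beyond the scatter) from compound 1 to compound 2 and a 1.9-fold higher number (0.28 log units; within the scatter) from compound 3 to compound 4, 2.7-fold (0.44 log units) apart, beyond the scatter of two such steps. Only on the core of compound 1 is the step beyond the scatter, while compound 3 and compound 4 cannot be told apart. For these two pairs the size of the step thus depends on the core, but two pairs give no rule for other cores and do not show which part of the cores accounts for the gap.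

The compounds shown leave open how a propylamino or a dimethylamino group in place of the ethylamino group would read on either core.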